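Hydroxy for methylsulfanyl on a fused triazine core

The source may hold more compounds than are shown below. What is called first, only, known or untested is meant among the compounds shown, and "the series" means these compounds.

Measured so far:
Compound 1, `CCCc1nc(C)c2c(C(C)C)nnc(O)n12`: > 48000 nM
Compound 2, `CCCc1nc(C)c2c(C)nnc(SC)n12`: > 48000 nM

Compound 1 was tested in a functional assay for inhibition, with Homo sapiens as the target (on this read-out higher numbers stand for weaker inhibition and lower numbers for stronger inhibition), and gave > 48000 nM, which is a limit of the assay rather than a number. Compound 2 in this assay likewise gave > 48000 nM, again a limit and not a number. Among the compounds with values here, compound 2 therefore stands at the limit of > 48000 nM in this assay, at which 2 of the 2 values shown sit, and no step between measured compounds can be read from the two results, since the two compounds differ in more than one place and both sit at the same limit.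

Compound 3, `CCCc1nc(C)c2c(C)nnc(O)n12`, has not yet been measured in this assay. It differs from compound 2 in one place: hydroxy in place of methylsulfanyl on an aromatic carbon. Because compound 2 sits at the limit of > 48000 nM in this assay, at which 2 of the 2 values shown sit, the step that the limit leaves unreadable from compound 2 to compound 3 is expected to be none beyond the scatter, with a large chance that only a limit is reported again. Compound 3 is accordingly estimated at 70000 nM in this assay, with a range from 20000 nM to 250000 nM.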

Compound 3, half-maximal inhibitory concentration: 14000 nM
Compound 3: the middle estimate sits 5.0-fold (0.70 log units) above what was measured; the whole stated range lies above it.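

In this assay compound 3 gives the first result in this series that is a number and not a limit, so the position on an aromatic carbon between two ring nitrogen atoms now shows a readable change: hydroxy in place of methylsulfanyl gives an at least 3.4-fold lower number from compound 2 to compound 3 (0.53 log units; beyond the scatter). Hydroxy alone is not enough, however, as compound 1 carries it too, and methyl in place of isopropyl on an aromatic carbon gives an at least 3.4-fold lower number from compound 1 to compound 3 (0.53 log units; beyond the scatter). Both steps are open-ended because each starts from a compound that sits at a limit of the assay and not at a number: the limit of > 48000 nM in this assay, at which 2 of the 3 values shown sit.

How far either step really reaches cannot be read, and the compounds shown do not tell how an amine or a methoxy group would compare with hydroxy at this position. Also open, on these data alone, is what an ethyl group or a longer chain would do in place of the methyl group that compound 3 carries where compound 1 has isopropyl.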